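Heteroaryl Versus Isopropyl on the Amide Nitrogen

The source may report more compounds than this note shows. Statements on the series, on what has been measured and on what is new or still open speak of the compounds shown alone.

Compound 1 `Cc1ccc(OCC(=O)N(Cc2cccs2)c2nccs2)cc1`: 2240 nM
Compound 2 `Cc1ccc(OCC(=O)N(Cc2cccs2)C(C)C)cc1`: 70 nM

In an assay on HEK293 cells for agonist activity at transient receptor potential cation channel subfamily M member 8 (Homo sapiens), read by fluorescence and calcium flux, with a stated time of 15 min (on this read-out lower numbers stand for an effect already at smaller amounts and higher numbers for an effect only at larger amounts of compound), compound 1 gives 2240 nM and compound 2 gives 70 nM, so compound 2 stands at the lower of the two numbers, and the measured change between them is a 32-fold lower number from compound 1 to compound 2 (1.51 log units; beyond the scatter). Compound 3 `Cc1ccc(OCC(=O)N(Cc2cccs2)c2nccn2C)cc1` differs from compound 2 by 1-methyl-1H-imidazol-2-yl in place of isopropyl on an amide-type nitrogen. Among the measured compounds shown here, the only step that bears on this change is the large one from 1,3-thiazol-2-yl to isopropyl on the same nitrogen. Since compound 3 again carries a five-membered aromatic ring there, a step in the opposite direction is expected, a 17-fold higher number from compound 2 to compound 3 (1.23 log units; beyond the scatter), its size less certain. Compound 3 is therefore estimated at 1200 nM, within a range from 300 nM to 5000 nM.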

Compound 3, half-maximal effective concentration: 1790 nM
Estimate against measurement, compound 3: 1.5-fold (0.17 log units) below, within the range that was stated.
By their numbers in this assay, from the lowest: compound 2; then compounds 3 and 1 (each within the scatter of the next).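

In this assay, 1-methyl-1H-imidazol-2-yl in place of isopropyl on the amide-type nitrogen gives a 26-fold higher number from compound 2 to compound 3 (1.41 log units; beyond the scatter), whereas in place of 1,3-thiazol-2-yl it gives a 1.3-fold lower number from compound 1 to compound 3 (0.10 log units; within the scatter). The large gap to isopropyl is thus not unique to 1,3-thiazol-2-yl, as it holds for both five-membered aromatic rings shown, which this assay does not separate. No measurement offered here accounts for this gap.

On these data alone, it remains open whether a cyclopropyl or tert-butyl group on this nitrogen would match isopropyl, and how a longer chain ending in an amine would fare.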